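Removing the Protected Amine from Compound 1

This account rests on a few compounds, and the source may have more. Where it says the series, first, only, none or still open, it means among the compounds named here.

Measured so far:
Compound 1 `COC(=O)C[C@H](NC(=O)OC(C)(C)C)C(=O)N(Cc1ccc(F)cc1)C1(C(=O)NCc2ccccc2)CCN(Cc2ccccc2)CC1`: > 100000 nM
Compound 2 `COC(=O)C[C@H](NC(=O)OC(C)(C)C)C(=O)N(Cc1ccc(F)cc1)C1(C(=O)NCc2ccccc2)CCN(C)CC1`: 17000 nM
Compound 3 `COC(=O)C[C@H](NC(=O)OC(C)(C)C)C(=O)N(C1CC1)C1(C(=O)NCc2ccccc2)CCN(Cc2ccccc2)CC1`: 84000 nM

All three were tested in an ADME assay on MDCK cells (Canis lupus familiaris) for cytotoxicity, read by microscopy, with a stated time of 72 h; a lower number here means that less compound is tolerated, a higher number that more compound is tolerated. For compound 1 the result is only a limit, (the limit of > 100000 nM in this assay, at which 1 of the 3 values shown sits), so where it truly stands is not known. Two changes from compound 1 have been measured. Taking hydrogen in place of phenyl on a saturated chain carbon bound to an amine nitrogen in a ring gave an at least 5.8-fold lower number from compound 1 to compound 2 (0.76 log units; beyond the scatter). Taking cyclopropyl in place of 4-fluorobenzyl on an amide-type nitrogen gave an at least 1.1-fold lower number from compound 1 to compound 3 (0.07 log units; that floor lies within the scatter).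

Compound 4 `COC(=O)CCC(=O)N(Cc1ccc(F)cc1)C1(C(=O)NCc2ccccc2)CCN(Cc2ccccc2)CC1` is the next step from compound 1: hydrogen in place of (tert-butoxycarbonyl)amino on a saturated chain carbon bound to a carbonyl carbon and a saturated chain carbon. Neither measured step removes this group, so the two steps only show what this assay does when compound 1 is pared down: one step moved the number beyond the scatter, the other did not. The (tert-butoxycarbonyl)amino group is larger than the phenyl whose loss gave the measured drop, so a move downward from the limit seems the more likely outcome, though staying at the limit cannot be ruled out.

Compound 4 is therefore expected at about 50000 nM, between 12000 nM and 100000 nM, which would mean an estimated at least 2.0-fold lower number from compound 1 to compound 4 (0.30 log units; that floor lies within the scatter).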

Compound 4, minimum cytotoxic concentration: 16000 nM
Beside the measured number, compound 4's estimate is 3.1-fold (0.49 log units) above it; low and high end bracket the measured number.
By their numbers in this assay, from the lowest: compounds 4 and 2 (each within the scatter of the next); then compound 3. At a limit, above all of these: compound 1.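

In this assay, the (tert-butoxycarbonyl)amino group on a saturated chain carbon bound to a carbonyl carbon and a saturated chain carbon proves to count for the tolerated amount: replacing it with hydrogen gives an at least 6.2-fold lower number from compound 1 to compound 4 (0.79 log units; beyond the scatter). This is a second place on compound 1 where a single change moves the number beyond the scatter, after the swap of phenyl for hydrogen that leads to compound 2, whereas the change that leads to compound 3 gives a floor within the scatter. The true size of the new step stays unknown, since its figure is only a floor set by the result for compound 1, which is a limit: the limit of > 100000 nM in this assay, at which 1 of the 4 values shown sits.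

Hydrogen replaces all 8 heavy atoms at once, so the result cannot show whether the nitrogen or the tert-butoxycarbonyl part matters more, and a free amine or an acetylamino group at this place would separate the two. As far as these compounds go, it also remains open whether the same loss would have a similar effect with methyl on the ring nitrogen, as in compound 2, or with cyclopropyl on the amide-type nitrogen, as in compound 3.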